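A 4-bromophenoxy group on the core of compound 1

The source may report more compounds than this note shows. Statements on the series, on what has been measured and on what is new or still open speak of the compounds shown alone.

Compound 1 (`C=C1CCC2[C@](C)(CO)[C@H](O)CC[C@@]2(C)[C@@H]1CCn1ccc(=O)[nH]c1=O`) was examined in a functional assay on RAW264.7 cells (Mus musculus) for inhibition, read by Griess assay, with stated times of 3 h and 24 h; on this read-out lower numbers stand for stronger inhibition and higher numbers for weaker inhibition. There compound 1 gives > 100000 nM as its result, which is a limit of the assay and not a number. Compound 2 (`C=C1CCC2C(C)(CO)[C@H](O)CC[C@@]2(C)[C@@H]1CCn1c(N)nccc1=O`) gives > 100000 nM in this assay as its result, and this too is a limit. Compound 1 thus stands with compound 2 at the limit of > 100000 nM in this assay, at which 2 of the 2 values shown sit, and has no number of its own.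

Compound 3 (`C=C1CCC2[C@](C)(CO)[C@H](O)CC[C@@]2(C)[C@@H]1CCOc1ccc(Br)cc1`) keeps the core of compound 1 and has one change, a group of 8 heavy atoms (6 carbon, 1 oxygen, 1 bromine; one six-membered aromatic ring of carbon only) in place of a group of 8 heavy atoms (4 carbon, 2 nitrogen, 2 oxygen; one six-membered aromatic ring with 2 hetero atoms), on a saturated chain carbon, two bonds along the chain from a saturated ring carbon as counted from the two structures. Among the compounds with values here, no measured step shows what such a change does in this assay and a move towards stronger inhibition is expected only tentatively, with a result at the same limit still possible. For compound 3 the expected value is 30000 nM within an estimated range of 6000 nM to 100000 nM in this assay. The estimated step of an at least 3.3-fold lower number from compound 1 to compound 3 (0.52 log units; beyond the scatter) is therefore modest.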

Compound 3, half-maximal inhibitory concentration: 40300 nM
Compound 3: the middle estimate sits 1.3-fold (0.13 log units) below what was measured, within the range that was stated.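

Putting 4-bromophenoxy in place of the earlier ring group, on a saturated chain carbon, two bonds along the chain from a saturated ring carbon, gives in this assay an at least 2.4-fold lower number from compound 1 to compound 3 (0.39 log units; beyond the scatter). Within the data shown here, this shows that a change at this one place on the shared core can bring a result inside the measurable range, which the earlier compounds could not show. The true size of the step remains unknown, since compound 3 alone has a number of its own and the other results are limits: the limit of > 100000 nM in this assay, at which 2 of the 3 values shown sit.

The compounds shown leave open whether the bromine, the ether oxygen or the carbon-only aromatic ring carries this step, which a plain phenoxy group or a chlorine in place of the bromine would help to separate. They also leave open how an amine, a carboxylic acid or a longer chain would read out at this place.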